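The source may report more compounds than this note shows. Statements on the series, on what has been measured and on what is new or still open speak of the compounds shown alone.

Compound 1 `Cn1c(-c2cc(-c3cccc(F)c3)on2)cc2ccccc21` was examined in a functional assay on COLO 320 cells (Homo sapiens) for cytotoxicity, read by WST assay, with a stated time of 72 h; a lower number here means a stronger inhibitor, a higher number a weaker inhibitor. In this assay compound 1 gives only a limit of the measurement, > 100000 nM. Two related compounds were examined in the same way. Compound 2 `COc1ccc(-c2cc(-c3cc4ccccc4n3C)no2)cc1` also gives only a limit in this assay, > 100000 nM. Compound 3 `COc1ccc(-c2cc(-c3cc4ccccc4n3C)on2)cc1` likewise gives only a limit in this assay, > 100000 nM. All three values sit at the limit of > 100000 nM in this assay, at which 3 of the 3 values shown sit. Compound 4 `COc1cccc(-c2cc(-c3cc4ccccc4n3C)no2)c1` has not yet been measured; it differs from compound 1 by methoxy in place of fluoro on an aromatic carbon. Going by the values given here, no step between measured compounds is available to guide the expectation. The step of a number no higher from compound 1 to compound 4 (the limit leaves the size open) is expected to be nothing beyond the usual scatter. Compound 4 is therefore expected to give about 100000 nM, somewhere between 30000 nM and 300000 nM.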

Compound 4, half-maximal inhibitory concentration: 69500 nM
For compound 4 the middle estimate is 1.4-fold (0.16 log units) above the measured one, within the range that was stated.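

In this assay compound 4 gives a measured number, 69500 nM, the first value shown here that is not a limit. Compound 1 gives only a limit, > 100000 nM. The change of methoxy in place of fluoro is therefore read as an at least 1.4-fold lower number from compound 1 to compound 4 (0.15 log units; that floor lies within the scatter), so its true size could be larger, but nothing shows a gain beyond the scatter.

As far as these compounds go, what an amine or a carboxylic acid would give on this aromatic carbon remains open. The wider picture also stays thin, as most values are still limits: the limit of > 100000 nM in this assay, at which 3 of the 4 values shown sit.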